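The source may report more compounds than this note shows. Statements on the series, on what has been measured and on what is new or still open speak of the compounds shown alone.

Compound 1 `COc1ccc(-c2cnc(NC(=O)c3ccco3)n2C)cc1` is the reference point of this account. In a toxicity assay on THP-1 cells (Homo sapiens) for inhibition (a lower number here means that less compound is tolerated, a higher number that more compound is tolerated), compound 1 gives no number but only a limit, > 100000 nM. Compound 3 `COc1ccc(-c2cnc(NC(=O)c3ccc(F)cc3)n2C2CCCC2)cc1` likewise gives only a limit in this assay, > 100000 nM. Among the measured compounds shown here, compound 2 `Cc1ccc(-c2cnc(NC(=O)c3ccc(F)cc3)n2C)cc1` is the one compound with a measured number, giving 60000 nM in this assay. Compound 1 thus sits at the limit of > 100000 nM in this assay, at which 2 of the 3 values shown sit. Compound 4 `COc1ccc(-c2cnc(NC(=O)c3ccccc3Br)n2C)cc1` has not yet been measured; it differs from compound 1 by 2-bromophenyl in place of furan-2-yl on a carbonyl carbon. No measured pair differs in only one place, so the size of such a change cannot be read from the data shown. The step from compound 1 to compound 4 is expected to be small, an at least 1.2-fold lower number from compound 1 to compound 4 (0.09 log units; that floor lies within the scatter), tending if anywhere downward. For compound 4 a value of 80000 nM is estimated, within a range from 30000 nM to 150000 nM.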

Compound 4, half-maximal cytotoxic concentration: > 100000 nM
Compound 4: no number, only a limit (the forecaster's own chance of this, stated with the estimate: 50%); at least 1.2-fold (0.09 log units) between middle value and limit.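

Compound 1 and compound 4 both give only a limit, so the step between them cannot be read. The compounds shown leave open how 2-bromophenyl and furan-2-yl truly compare, with most values stopping at one point: the limit of > 100000 nM in this assay, at which 3 of the 4 values shown sit.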